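Trading a Phenyl for a Methyl on the Shared Core

This account rests on a few compounds, and the source may have more. Where it says the series, first, only, none or still open, it means among the compounds named here.

Compound 1, `OC(CCn1nc2c(Br)c(Br)c(Br)c(Br)c2n1)c1cccc(Cl)c1`: 12%
Compound 2, `OC(CCn1nc2c(Br)c(Br)c(Br)c(Br)c2n1)c1ccccc1`: 23%

In a functional assay on MCF7 cells (Homo sapiens) for antiproliferative activity, read by MTT assay, with a stated time of 48 h, tested at 50 uM (a lower number here means a stronger effect, a higher number a weaker effect of the compound at the concentration tested), compound 2 gives 23%, the highest of the two numbers measured. Going by the values given here, the only measured step, a number 11 percentage points higher from compound 1 to compound 2 (beyond the scatter), concerns a different part of the molecule, where a chloro was exchanged for hydrogen. Compound 3, `CC(O)CCn1nc2c(Br)c(Br)c(Br)c(Br)c2n1`, differs from compound 2 by methyl in place of phenyl on a saturated chain carbon bound to an oxygen on a saturated carbon and a saturated chain carbon. Among the compounds with values here, no measured step bears on this change, which removes a whole ring rather than a single substituent, so a further weakening is expected only by guess. The value of compound 3 is estimated at 40%, within 20% to 70%. This estimate means an expected step of a number 17 percentage points higher from compound 2 to compound 3 (beyond the scatter).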

Compound 3, a percentage reported as activity, at one concentration (the size of the read-out at that concentration, not a potency): 76%
Compound 3: middle estimate off by 36 percentage points, on the low side; the whole stated range lies below it.
By their numbers in this assay, from the lowest: compound 1; then compound 2; then compound 3.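

In this assay, the group on this saturated chain carbon bound to an oxygen weighs far more than the chloro on the ring: methyl in place of phenyl gives a number 53 percentage points higher from compound 2 to compound 3 (beyond the scatter), well beyond the earlier a number 11 percentage points higher from compound 1 to compound 2 (beyond the scatter). Methyl in place of 3-chlorophenyl gives a number 64 percentage points higher from compound 1 to compound 3 (beyond the scatter), so nearly all of the effect at this concentration goes once the ring goes. Nothing measured yet explains why this step is so large. Still open, as far as these compounds go, is whether any ring is needed here, or whether a longer chain such as butyl or a saturated cyclohexyl would do as well as phenyl. An amine on the phenyl ring is likewise an open case.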